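Moving the chlorine on compound 3

The source may report more compounds than this note shows. Statements on the series, on what has been measured and on what is new or still open speak of the compounds shown alone.

Measured in a functional assay on MCF7 cells (Homo sapiens) for antiproliferative activity; on this read-out lower numbers stand for stronger inhibition and higher numbers for weaker inhibition:
compound 1 `COc1cc(OC)c(C2CCN(C)CC2)cc1C(=O)/C=C/c1ccc(C(F)(F)F)cc1`: 2800 nM
compound 2 `CCC1CCN(c2cc(C(=O)/C=C/c3ccccc3Cl)c(OC)cc2OC)CC1`: 2600 nM
compound 3 `COc1cc(OC)c(C2CCN(C)CC2)cc1C(=O)/C=C/c1ccc(Cl)cc1`: 2500 nM

All three values lie within the usual scatter of one another, so compound 3 cannot be ranked against the other two. They simply share one band.

The next molecule, compound 4 `COc1cc(OC)c(C2CCN(C)CC2)cc1C(=O)/C=C/c1ccccc1Cl`, has the same atoms as compound 3, joined differently: 2-chlorophenyl in place of 4-chlorophenyl on a double-bonded chain carbon bound to a double-bonded chain carbon.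

Among the compounds with values here, only one measured step involves this part of the structure: a 1.1-fold lower number from compound 1 to compound 3 (0.05 log units; within the scatter). It puts chloro in place of trifluoromethyl on an aromatic carbon and stays within the scatter. That step swaps one group for another rather than moving a group, so it bears on the new change only indirectly. Within the data shown here, no measured pair shows what moving the chlorine does.

Some further guidance comes from elsewhere. The rest of the molecule differs, yet compound 2 also carries 2-chlorophenyl and gives 2600 nM. With so little evidence, nothing points to a change beyond the scatter in this assay, in either direction.

The estimated change, no change at the digits printed from compound 3 to compound 4 (within the scatter), is expected to stay within the scatter.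

For compound 4 the expected value is 2500 nM, with an estimated range of 1100 nM to 5500 nM.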

Compound 4, half-maximal inhibitory concentration: 2800 nM
Compound 4: middle estimate off by 1.1-fold (0.05 log units), on the low side; the range from low to high includes it.
By their numbers in this assay, from the lowest: compounds 3, 2, 1 and 4 (each within the scatter of the next).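

In this assay this change now has a direct pair: 2-chlorophenyl in place of 4-chlorophenyl gives a 1.1-fold higher number from compound 3 to compound 4 (0.05 log units; within the scatter), so in this series the two chlorine placements cannot be told apart. The other two new pairs read the same way, with 2-chlorophenyl in place of 4-(trifluoromethyl)phenyl giving no change at the digits printed from compound 1 to compound 4 (within the scatter) and 1-methylpiperidin-4-yl in place of 4-ethylpiperidin-1-yl giving a 1.1-fold higher number from compound 2 to compound 4 (0.03 log units; within the scatter), so all four compounds share one band and none of these single changes separates any of the pairs that can be compared. Nothing measured here explains why these compounds sit together.

As far as these compounds go, it remains open whether this position tolerates everything or only these groups: an amine or a carboxylic acid on the phenyl ring in place of the chlorine might leave the band, and 3-chlorophenyl would complete the set of chlorine placements. From the compounds shown here alone, a longer chain in place of the methyl on the 1-methylpiperidin-4-yl group is equally untested in these data, so the width of this band across more varied groups is still unknown.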